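Swapping the Aryl Group: What to Expect for Compound 4

The compounds below may be only part of what the source reports. "The series", "measured", "known", "first", "only" and "open" are said of these compounds alone.

Of the compounds shown here, three have been measured in an assay on blood for inhibition of C-X-C chemokine receptor type 3 (Homo sapiens), with a stated time of 30 min; a higher number here means a weaker inhibitor, a lower number a stronger inhibitor. Compound 1 `Cc1nc(-c2nc3ccccc3[nH]2)c(N2CCN(C(=O)Cn3cnc4cccnc43)[C@H](C)C2)s1` gives 1060 nM, compound 2 `C[C@@H]1CN(c2sc(CO)nc2-c2nc3ccccc3[nH]2)CCN1C(=O)Cn1cnc2cccnc21` gives 3380 nM, and compound 3 `COc1ccc(-c2nc(C(F)(F)F)sc2N2CCN(C(=O)Cn3cnc4cccnc43)[C@H](C)C2)cc1` gives 1190 nM. Compound 3 therefore stands second highest of the three numbers: its value and that of compound 1 lie within the usual scatter of each other, while the gap to compound 2 is beyond it. Within the data shown here, the only measured step, a 3.2-fold higher number from compound 1 to compound 2 (0.50 log units; beyond the scatter), concerns a different change on the shared core and does not bear on the one considered here. Compound 4 `CCCc1ncc(-c2nc(C(F)(F)F)sc2N2CCN(C(=O)Cn3cnc4cccnc43)[C@H](C)C2)cn1` differs from compound 3 by 2-propylpyrimidin-5-yl in place of 4-methoxyphenyl on an aromatic carbon. Among the measured compounds shown here, with no measured step touching this change, no shift beyond the scatter is expected in this assay. The estimate for compound 4 is 1300 nM, between 400 nM and 4000 nM. That expectation amounts to a 1.1-fold higher number from compound 3 to compound 4 (0.04 log units; within the scatter).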

Compound 4, half-maximal inhibitory concentration: 45 nM
Beside the measured number, compound 4's estimate is 29-fold (1.46 log units) above it, and the stated range ends above it.
By their numbers in this assay, from the lowest: compound 4; then compounds 1 and 3 (each within the scatter of the next); then compound 2.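

In this assay, this position on the five-membered ring proves highly sensitive to the group it carries: 2-propylpyrimidin-5-yl in place of 4-methoxyphenyl gives a 26-fold lower number from compound 3 to compound 4 (1.42 log units; beyond the scatter), the largest step seen so far. The swap alters both the ring, now with two hetero atoms, and its side chain, so the two changes cannot be told apart. No measurement here explains the step. Still open, as far as these compounds go, is which part matters: a 4-propylphenyl group or a bare pyrimidin-5-yl would separate them. A butyl chain or an amine on the pyrimidine would show how much room for change this group allows.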